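Fluorophenyl variation and adenosine receptor displacement at one concentration

This account rests on a few compounds, and the source may have more. Where it says the series, first, only, none or still open, it means among the compounds named here.

Measured compounds:
compound 1 `Nc1scc(CN2CCN(c3ccccc3C(F)(F)F)CC2)c1C(=O)c1ccc(Cl)cc1`: 0%
compound 2 `Nc1scc(CN2CCN(c3cccc(F)c3)CC2)c1C(=O)c1ccc(Cl)cc1`: 1%
compound 3 `Nc1scc(CN2CCN(c3ccccc3F)CC2)c1C(=O)c1ccc(Cl)cc1`: 4%

All three numbers come from an assay on CHO cells for displacement of a labelled ligand from adenosine receptor A1 (Homo sapiens), read by scintillation counting, with a stated time of 120 min, tested at 10 uM; a higher number here means more inhibition at the concentration tested (going by the name of the read-out), a lower number less inhibition. Compound 3 sits together with compound 1 and compound 2: the step of a number 4 percentage points higher from compound 1 to compound 3 (within the scatter) and the step of a number 3 percentage points higher from compound 2 to compound 3 (within the scatter) are both within the scatter, as is the step of a number 1 percentage points higher from compound 1 to compound 2 (within the scatter), so the three phenyl variants cannot be told apart on these data, and none of them shows appreciable inhibition.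

Compound 4 `Nc1scc(CN2CCN(c3ccc(F)cc3F)CC2)c1C(=O)c1ccc(Cl)cc1` differs from compound 3 by fluoro in place of hydrogen on an aromatic carbon. Going by the values given here, the measured steps that bear on this are the exchange of trifluoromethyl for fluoro, a number 4 percentage points higher from compound 1 to compound 3 (within the scatter), and the move of fluoro from one phenyl position to another, a number 3 percentage points higher from compound 2 to compound 3 (within the scatter); neither moved the read-out beyond the scatter, and no measured step adds a second fluoro. The expected step of a number 1 percentage points lower from compound 3 to compound 4 (within the scatter) is therefore one that stays within the scatter, with no direction implied. Compound 4 is estimated at 3%, with a range from -5% to 12%.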

Compound 4, a percentage reported as inhibition, at one concentration (the size of the read-out at that concentration, not a potency): 1%
Estimate against measurement, compound 4: 2 percentage points above, within the range that was stated.
By their numbers in this assay, from the lowest: compounds 1, 2, 4 and 3 (each within the scatter of the next).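

In this assay, going by these compounds alone, a second fluoro on the aromatic carbon para to a large group and meta to a fluoro group gives a number 3 percentage points lower from compound 3 to compound 4 (within the scatter) and thus stays within the scatter; this is the first step that adds a fluoro rather than exchanging or moving one. The other new steps (no change at the digits printed from compound 2 to compound 4 (within the scatter) and a number 1 percentage points higher from compound 1 to compound 4 (within the scatter)) also stay within the scatter, so 2,4-difluorophenyl cannot be told apart from 3-fluorophenyl or 2-(trifluoromethyl)phenyl on these data. No evidence bearing on this result is available.

From the compounds shown here alone, whether an amine, a carboxylic acid or a methoxy group at this position would move the read-out beyond the scatter remains open. Also open, going by these compounds, is whether any change to the shared core would give appreciable inhibition.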